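Swapping methoxy for cyano: expected cytotoxicity of compound 4

The source may report more compounds than this note shows. Statements on the series, on what has been measured and on what is new or still open speak of the compounds shown alone.

Compound 3 `COc1ccc(-c2cc(C)c3ncc(CSCCc4ccccc4)n3c2)cc1` holds the higher of the two numbers recorded in an ADME assay on HEL cells (Homo sapiens) for cytotoxicity, with a stated time of 3 days; on this read-out higher numbers stand for lower toxicity in this test and lower numbers for higher toxicity in this test: compound 3 gives 25.8 ug/mL. Its nearest neighbour is compound 1 `Cc1cc(-c2cccc(O)c2)c2ncc(CSCCc3ccccc3)n2c1`, which in this assay gives 11.4 ug/mL, a gap that lies beyond the scatter of repeated measurements. Compound 2 `COc1cccc(-c2cc(C)cn3c(CSCCc4ccccc4)cnc23)c1` sits at a limit of this assay, which compound 2 reports as > 50 ug/mL. Among the measured compounds shown here, the one measured step, an at least 4.3-fold higher number from compound 1 to compound 2 (0.64 log units; beyond the scatter), comes from a methyl replacing a hydrogen on an oxygen, and its size is only known as a minimum because of the limit of > 50 ug/mL in this assay, at which 1 of the 3 values shown sits.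

Compound 4 `Cc1cc(-c2ccc(C#N)cc2)cn2c(CSCCc3ccccc3)cnc12` differs from compound 3 by cyano in place of methoxy on an aromatic carbon. For the measured compounds named here, no measured step involves a cyano group or the removal of a methoxy, so the single step available gives no guidance on this change. With nothing to point in either direction, the expected step of a 1.0-fold lower number from compound 3 to compound 4 (0.01 log units; within the scatter) is none beyond the scatter. Compound 4 is therefore estimated at 25 ug/mL, with a range from 10 ug/mL to 50 ug/mL.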

Compound 4, half-maximal cytotoxic concentration: 10.6 ug/mL
The estimate for compound 4 lay 2.4-fold (0.37 log units) above the measured number, within the range that was stated.
By their numbers in this assay, from the lowest: compounds 4 and 1 (each within the scatter of the next); then compound 3. At a limit, above all of these: compound 2.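

Cyano in place of methoxy gives a 2.4-fold lower number from compound 3 to compound 4 (0.39 log units; beyond the scatter) in this assay, so the group on this aromatic carbon, para to a large group, does shift the number, here towards higher toxicity in this test. Among the compounds shown here, the only earlier step, a methyl replacing a hydrogen on an oxygen, moved the number the other way, an at least 4.3-fold higher number from compound 1 to compound 2 (0.64 log units; beyond the scatter), but it concerns a different group on a different compound. Nothing shown here gives a measured reason for the drop from methoxy to cyano.

The compounds shown leave open whether the step comes from losing methoxy or from gaining cyano, a question that a plain hydrogen or an amine on this carbon could help to settle. Also open, on these data alone, is whether a longer chain, such as ethoxy, would keep the number of compound 3.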